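A few compounds are considered here, and "the series" means these few. Any claim that something is new, unique, unknown or untested is made for them only; others in the source may bear on it.

Compound 1 `O=C(c1ccccc1)c1cc(C(=O)c2ccccc2)c(=O)[nH]c1-c1ccccc1` gives 1.76% in an assay on isolated protein for inhibition of 3',5'-cyclic-AMP phosphodiesterase 4A (Cavia porcellus), read by cAMP accumulation, tested at 10 uM; a higher number here means a stronger effect of the compound at the concentration tested, a lower number a weaker effect. Compound 2 `O=C1CC(c2ccccc2)Cc2[nH]c(=O)c(C(=O)c3ccccc3)cc21` gives 5.2% in this assay; compound 2 and compound 1 sit within the scatter of each other, so neither stands apart, and both read-outs are small. Compound 3 `CC(C)(C)C(=O)c1cc2c([nH]c1=O)CC(c1ccccc1)CC2=O` differs from compound 2 by a single change: tert-butyl in place of phenyl on a carbonyl carbon. For the measured compounds named here, no measured pair shows this change, so its size in this assay is unknown. With both measured compounds reading small, the expected step is a number 1.2 percentage points lower from compound 2 to compound 3 (within the scatter), within the scatter and in no set direction. Compound 3 is expected to give 4%, in the range 0% to 15%.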

Compound 3, a percentage reported as inhibition, at one concentration (the size of the read-out at that concentration, not a potency): 0.8%
Compound 3: middle estimate off by 3.2 percentage points, on the high side, within the range that was stated.
By their numbers in this assay, from the lowest: compounds 3, 1 and 2 (each within the scatter of the next).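

Tert-butyl in place of phenyl on a carbonyl carbon reads as a number 4.4 percentage points lower from compound 2 to compound 3 (within the scatter) in this assay and so does not separate the two groups. A group with no ring therefore reads in the same small range as phenyl at this position, and the read-out stays small with both groups on the shared core. As far as these compounds go, whether any group on this carbonyl carbon can lift the read-out stays open, for instance an amine, a carboxylic acid or a longer chain. No measurement bearing on the reason for this step is available.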